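Swapping a fluorophenyl for a bromophenyl on the amidoxime carbon

The compounds below may be only part of what the source reports. "The series", "measured", "known", "first", "only" and "open" are said of these compounds alone.

Compound 1 `O=[N+]([O-])c1ccc(N/C(=N\O)c2ccccc2F)c2nonc12` gives the lowest number of the three measured in an assay on isolated protein for inhibition of Indoleamine 2,3-dioxygenase 1 (Homo sapiens), read by spectrophotometry, with a stated time of 1 h (a lower number here means a stronger inhibitor, a higher number a weaker inhibitor), at 63 nM. Compound 3 `O=[N+]([O-])c1ccc(N/C(=N\O)c2ccc(Cl)cc2)c2nonc12` stands nearest, at 113 nM, and compound 2 `Cc1cccc(/C(=N/O)Nc2ccc([N+](=O)[O-])c3nonc23)c1` furthest, at 163 nM. Compound 4 `O=[N+]([O-])c1ccc(N/C(=N\O)c2ccc(Br)cc2)c2nonc12` has not yet been measured; it differs from compound 1 in that (4-bromophenyl in place of 2-fluorophenyl on a carbon with a double bond to nitrogen). The step that bears most closely on this change is a 1.8-fold higher number from compound 1 to compound 3 (0.25 log units; within the scatter), where 4-chlorophenyl likewise enters in place of 2-fluorophenyl; the step of a 2.6-fold higher number from compound 1 to compound 2 (0.41 log units; beyond the scatter) shows a modest loss for a different ring. Compound 4 is therefore expected to show a small rise of about a 1.7-fold higher number from compound 1 to compound 4 (0.22 log units; within the scatter) in this assay, likely within the scatter. Compound 4 is estimated at 105 nM, in a range from 50 nM to 220 nM.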

Compound 4, half-maximal inhibitory concentration: 117 nM
Estimate against measurement, compound 4: 1.1-fold (0.05 log units) below; measured number inside the range.
By their numbers in this assay, from the lowest: compounds 1, 3, 4 and 2 (each within the scatter of the next, the first and the last beyond it).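

In this assay, 4-bromophenyl and 4-chlorophenyl cannot be told apart on this carbon (a 1.0-fold higher number from compound 3 to compound 4 (0.02 log units; within the scatter)), so bromo serves here as well as chloro. The 4-bromophenyl group also lies within the scatter of both other rings (a 1.9-fold higher number from compound 1 to compound 4 (0.27 log units; within the scatter)) (a 1.4-fold lower number from compound 2 to compound 4 (0.14 log units; within the scatter)), although those two rings are separated by a step beyond it. The compounds shown leave open whether an amine or a carboxylic acid on the phenyl ring, in place of the halogen, would keep the number in this range. Nothing available explains why the two halogens read alike.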